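This account rests on a few compounds, and the source may have more. Where it says the series, first, only, none or still open, it means among the compounds named here.

Working notes on the series, read in a functional assay on SW-620 cells (Homo sapiens) for cytotoxicity; on this read-out lower numbers stand for stronger inhibition of growth and higher numbers for weaker inhibition of growth. Compound 1 `COc1ccc(C2=C(c3ccc(SC)cc3)CC3CCCN3C2=O)cc1O` gives 20000 nM, compound 2 `COc1ccc(C2=C(c3ccc(SC)cc3)CC3CCCN3C2=O)cc1Br` gives 5000 nM, and compound 3 `CSc1ccc(C2=C(c3ccc(C)c(C)c3)C(=O)N3CCCC3C2)cc1` gives 700 nM, the lowest number of the three. The next member is compound 4 `CSc1ccc(C2=C(c3ccc(O)c(O)c3)C(=O)N3CCCC3C2)cc1`, which carries 3,4-dihydroxyphenyl in place of 3,4-dimethylphenyl on a double-bonded ring carbon, next to the ring atom that bears a 4-(methylsulfanyl)phenyl group: 3,4-dihydroxyphenyl in place of 3,4-dimethylphenyl on a double-bonded ring carbon.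

Among the compounds with values here, two measured steps concern this same place. The first, a 29-fold lower number from compound 1 to compound 3 (1.46 log units; beyond the scatter), is large and ends on 3,4-dimethylphenyl, starting from 3-hydroxy-4-methoxyphenyl. The second, a 7.1-fold lower number from compound 2 to compound 3 (0.85 log units; beyond the scatter), is modest and starts from 3-bromo-4-methoxyphenyl. Within that aryl group, a 4.0-fold lower number from compound 1 to compound 2 (0.60 log units; beyond the scatter) is also modest, with bromo in place of hydroxy. Within the data shown here, no measured compound carries 3,4-dihydroxyphenyl, which leaves the reading indirect. Leaving 3,4-dimethylphenyl has so far meant a higher number, and compound 1, the only hydroxy-bearing example, sits furthest up at 20000 nM. A modest to large step towards a higher number is therefore expected in this assay. The estimate means an 8.6-fold higher number from compound 3 to compound 4 (0.93 log units; beyond the scatter), an expected weakening of growth inhibition. Compound 4 is estimated at 6000 nM, with an expected range of 1500 nM to 25000 nM.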

Compound 4, concentration for 50% growth inhibition: 50000 nM
For compound 4 the middle estimate is 8.3-fold (0.92 log units) below the measured one, and the stated range ends below it.
By their numbers in this assay, from the lowest: compound 3; then compound 2; then compound 1; then compound 4.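

In this assay the 3,4-dihydroxyphenyl group extends the spread at this position: it moves the series far from its lowest member, with a 71-fold higher number from compound 3 to compound 4 (1.85 log units; beyond the scatter) and with a 10-fold higher number from compound 2 to compound 4 (1.00 log units; beyond the scatter) on the same ring carbon. Compared with 3-hydroxy-4-methoxyphenyl, the only earlier hydroxy-bearing group, exchanging methyl for hydrogen on the oxygen gives a 2.5-fold higher number from compound 1 to compound 4 (0.40 log units; beyond the scatter) and so shows that the methoxy of compound 1 does not account for its high number. Across these four compounds, the two carrying a hydroxy group have the highest numbers and no compound goes against that order, though this rests on two hydroxy-bearing examples only. No measurement on hand accounts for these differences.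

The compounds shown leave open whether one hydroxy group alone, as in 3-hydroxyphenyl or 4-hydroxyphenyl, gives most of the rise, and whether 3,4-dimethoxyphenyl returns the number towards that of compound 3. They also leave open how an amine or a carboxylic acid on the same aryl ring would read, and whether either methyl group of 3,4-dimethylphenyl would suffice alone.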